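Pyridinyl Alkyne in Place of Methylphenyl Alkyne

The source may hold more compounds than are shown below. What is called first, only, known or untested is meant among the compounds shown, and "the series" means these compounds.

Measured compounds: compound 1, `CC(C)NC(=O)c1ccc(C#Cc2ccccc2)nc1`; compound 2, `O=C(NC1CCCC1)c1ccc(C#Cc2cccnc2)nc1`; compound 3, `Cc1ccccc1C#Cc1ccc2c(n1)CCN(C)C2=O`.

In an assay on HEK293 cells for displacement of a labelled ligand from metabotropic glutamate receptor 5 (Homo sapiens), with a stated time of 2 h (on this read-out lower numbers stand for stronger inhibition and higher numbers for weaker inhibition), compound 1 gives 7100 nM. Compound 2 reaches only the limit of this assay, > 32000 nM. Compound 3 likewise shows only the limit of this assay, > 32000 nM, so no number is known for it; it sits where 2 of the 3 values shown sit, (the limit of > 32000 nM in this assay, at which 2 of the 3 values shown sit). Compound 1 is the only one of the three with a number inside the range of this assay.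

The unmeasured compound 4, `CN1CCc2nc(C#Cc3cccnc3)ccc2C1=O`, keeps the core of compound 3 and differs from it in one place: pyridin-3-yl in place of 2-methylphenyl on a triple-bonded carbon, on a triple-bonded carbon whose other neighbour is a triple-bonded carbon. Compound 2 already carries a pyridin-3-yl on its alkyne and gives only a limit, and compound 3 gives only a limit with the 2-methylphenyl. No step beyond the scatter in this assay is therefore expected in either direction; the expected step that the limit leaves unreadable from compound 3 to compound 4 is one of no change. Compound 4 is thus expected to give about 40000 nM in this assay, within a range from 10000 nM to 150000 nM, most likely reported again as a limit.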

Compound 4, inhibition constant: 27400 nM
Compound 4: the middle estimate sits 1.5-fold (0.16 log units) above what was measured, and the stated range covers the measured number.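

In this assay compound 4 gives 27400 nM, the first number inside the range of the read-out for this core, so a pyridin-3-yl on the triple-bonded carbon leaves the core with a readable value. Among these compounds, the change from 2-methylphenyl to pyridin-3-yl gives an at least 1.1-fold lower number from compound 3 to compound 4 (0.06 log units; that floor lies within the scatter); that floor lies within the usual scatter, so the step shows no certain gain, only that the swap costs nothing that can be seen here. The true size of the step cannot be read because compound 3 stands at a limit: the limit of > 32000 nM in this assay, at which 2 of the 4 values shown sit.

The compounds shown leave open how far the real step lies beyond that floor, and so whether the ring nitrogen of the pyridin-3-yl matters at all on this core. They also leave open how the read-out would respond on this same core to other groups on the triple-bonded carbon, such as a pyrimidin-5-yl or a 3-fluorophenyl.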